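From methoxycarbonyl to propylcarbamoyl on a shared core

A few compounds are considered here, and "the series" means these few. Any claim that something is new, unique, unknown or untested is made for them only; others in the source may bear on it.

- compound 1 `CCOC(=O)c1cccc(-c2nn(Cc3ccccc3)c3ccccc23)c1`: > 10000 nM
- compound 2 `CCOC(=O)c1ccc(-c2nn(Cc3ccncc3)c3ccccc23)cc1`: 5630 nM
- compound 3 `COC(=O)c1ccc(-c2nn(Cc3ccccc3)c3ccccc23)cc1`: 560 nM

All three compounds were tested in a functional assay on cells (Platelet, Homo sapiens) for inhibition; on this read-out higher numbers stand for weaker inhibition and lower numbers for stronger inhibition. For compound 1, the reading of > 10000 nM is a limit and not a number. Of the two true numbers, compound 3 has the lower at 560 nM, and compound 2 gives 5630 nM. That gap lies beyond the scatter.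

The next compound is compound 4 `CCCNC(=O)c1ccc(-c2nn(Cc3ccccc3)c3ccccc23)cc1`. It keeps the core of compound 3 but carries propylamino in place of methoxy on a carbonyl carbon. The same difference can be read as methoxycarbonyl to propylcarbamoyl.

Among the compounds with values here, no measured pair of compounds shows this change on its own, so the expectation is uncertain. The expected change is a 4.5-fold higher number from compound 3 to compound 4 (0.65 log units; beyond the scatter), toward weaker inhibition and beyond the scatter. For compound 4 the estimated value in this assay is 2500 nM, with an expected range of 600 nM to 10000 nM.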

Compound 4, half-maximal inhibitory concentration: > 10000 nM
Compound 4 ended at the assay's limit; the forecaster's own chance of this, stated with the estimate: 25%; at least 4.0-fold (0.60 log units) between middle value and limit.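

In this assay, within the data shown here, propylamino in place of methoxy on a carbonyl carbon gives an at least 17-fold higher number from compound 3 to compound 4 (1.25 log units; beyond the scatter), the first comparison here between compounds that differ in one place, and it shows that this position does not tolerate every change. Compound 4 reads > 10000 nM, which is a limit and not a number. The full size of the step therefore remains unknown, because the reading for compound 4 is a limit: the limit of > 10000 nM in this assay, at which 2 of the 4 values shown sit.

The compounds shown leave open whether the step goes with the amide hydrogen or with the length of the chain, which a methylamino or a dimethylamino group on the same carbonyl carbon would help to separate. They also leave open how a carboxylic acid in this place would read in this assay.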